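The source may report more compounds than this note shows. Statements on the series, on what has been measured and on what is new or still open speak of the compounds shown alone.

Going by the values given here, in a functional assay on HeLa cells (Homo sapiens) for antiproliferative activity, read by CCK-8 assay, with a stated time of 48 h (on this read-out higher numbers stand for weaker inhibition and lower numbers for stronger inhibition), compound 2 `O=c1c2ccccc2[se]n1-c1nc(SCc2ccc(Cl)cc2)n[nH]1` gives 40900 nM, one of only two numbers measured so far, and it sits within the scatter of the value of compound 1 `CCCCCCSc1n[nH]c(-n2[se]c3ccccc3c2=O)n1`, which gives 35900 nM. Among the compounds with values here, the single measured step runs a 1.1-fold higher number from compound 1 to compound 2 (0.06 log units; within the scatter), so swapping a plain chain for the ring-bearing group at that place left the read-out essentially unchanged. Compound 3 `CCCCCSc1n[nH]c(-n2[se]c3ccccc3c2=O)n1` has not yet been measured. Within the data shown here, it differs from compound 2 by butyl in place of 4-chlorophenyl on a saturated chain carbon bound to a sulfur, which is close to the reverse of the one measured step, returning to a chain one carbon shorter than before. The step of a 1.1-fold lower number from compound 2 to compound 3 (0.04 log units; within the scatter) is expected to stay within the scatter because a 1.1-fold higher number from compound 1 to compound 2 (0.06 log units; within the scatter) also stayed there. Compound 3 is therefore expected to give about 37000 nM, with a plausible range from 15000 nM to 90000 nM.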

Compound 3, half-maximal inhibitory concentration: 30300 nM
The estimate for compound 3 lay 1.2-fold (0.09 log units) above the measured number; the measured number falls inside the stated range.
By their numbers in this assay, from the lowest: compounds 3, 1 and 2 (each within the scatter of the next).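

In this assay, butyl in place of 4-chlorophenyl on a saturated chain carbon bound to a sulfur gives a 1.3-fold lower number from compound 2 to compound 3 (0.13 log units; within the scatter), so a second exchange between a ring-bearing group and a plain chain also stays within the scatter. Going by these compounds alone, this compound also allows the first comparison of two plain chains: hydrogen in place of methyl on a saturated chain carbon, five bonds along the chain from a sulfur, gives a 1.2-fold lower number from compound 1 to compound 3 (0.07 log units; within the scatter), so trimming the chain end leaves the read-out within the scatter too. Compound 1, compound 2 and compound 3 thus sit within the scatter at this place, and no measurement at hand explains this.

On these data alone, whether a much longer chain, or a chain ending in an amine or a carboxylic acid, would move the number at this place stays open. The compounds also leave open how changes to the shared core would affect the read-out.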